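Chloro added to compound 3: expected shift

The source may hold more compounds than are shown below. What is called first, only, known or untested is meant among the compounds shown, and "the series" means these compounds.

Among the measured compounds shown here, compound 3 `CC1CN(c2ccccc2)NC(=O)N1O` gives 13000 nM in a functional assay on cells for inhibition of Polyunsaturated fatty acid 5-lipoxygenase (Homo sapiens) (a higher number here means a weaker inhibitor, a lower number a stronger inhibitor), the highest of the three numbers measured so far. Compound 2 `COc1cccc(N2CCNC(=O)N2)n1` gives 3500 nM in this assay, and compound 1 `CC1CN(c2cccc(Cl)c2)NC(=O)N1` gives 2700 nM; both gaps to compound 3 lie beyond the scatter. Compound 4 `CC1CN(c2cccc(Cl)c2)NC(=O)N1O` differs from compound 3 by chloro in place of hydrogen on an aromatic carbon. For the measured compounds named here, no measured pair shows this change alone; compound 1 carries the same chloro, but on a core that also differs from that of compound 3 in another place, so its number offers only a loose pointer. The expected step is a 2.4-fold lower number from compound 3 to compound 4 (0.37 log units; beyond the scatter), a modest downward move. In this assay compound 4 is expected at 5500 nM, within 1800 nM to 16000 nM.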

Compound 4, half-maximal inhibitory concentration: 3600 nM
Compound 4: middle estimate off by 1.5-fold (0.18 log units), on the high side; measured number inside the range.
By their numbers in this assay, from the lowest: compounds 1, 2 and 4 (each within the scatter of the next); then compound 3.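

In this assay, among the compounds shown here, chloro in place of hydrogen on an aromatic carbon, meta to a group of 9 heavy atoms, gives a 3.6-fold lower number from compound 3 to compound 4 (0.56 log units; beyond the scatter), the first direct reading of this change at this position. With that chloro in place, hydroxy in place of hydrogen on an amide-type nitrogen in a ring gives a 1.3-fold higher number from compound 1 to compound 4 (0.12 log units; within the scatter), so this pair separates no effect of the hydroxy. As far as these compounds go, how a nitrile or a carboxylic acid in place of the chloro would move the number stays open. No measurement at hand gives a cause for either step.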